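A few compounds are considered here, and "the series" means these few. Any claim that something is new, unique, unknown or untested is made for them only; others in the source may bear on it.

In an assay on cells for inhibition of Voltage-dependent T-type calcium channel subunit alpha-1I (Homo sapiens), read by patch clamp, tested at 10 uM (a higher number here means more inhibition at the concentration tested (going by the name of the read-out), a lower number less inhibition), three compounds have been measured:

Compound 1, `CN(C)CCCCCSC1=Nc2ccccc2C(CC(=O)NCc2ccccc2)N1c1ccc(-c2ccccc2)cc1`, gives 85.6%.
Compound 2, `O=C(CC1c2ccccc2N=C(SCCCCCN2CCCC2)N1c1ccc(-c2ccccc2)cc1)NCc1ccccc1`, gives 92.7%.
Compound 3, `CN(C)CCCCCSC1=Nc2ccccc2C(CC(=O)NCc2ccccc2)N1c1ccccc1`, gives 76%.

Compound 2 differs from compound 1 by pyrrolidin-1-yl in place of dimethylamino on a saturated chain carbon, five bonds along the chain from a sulfur, and this change made the step of a number 7.1 percentage points higher from compound 1 to compound 2 (within the scatter). Compound 3 differs from compound 1 by hydrogen in place of phenyl on an aromatic carbon, with the step of a number 9.6 percentage points lower from compound 1 to compound 3 (within the scatter). Among the compounds with values here, no step is counted between compound 3 and compound 2; their two values show a gap beyond the scatter. Compound 4, `O=C(CC1c2ccccc2N=C(SCCCCCN2CCCC2)N1c1ccccc1)NCc1ccccc1`, has not yet been measured; it differs from compound 3 by pyrrolidin-1-yl in place of dimethylamino on a saturated chain carbon, five bonds along the chain from a sulfur, the same change as from compound 1 to compound 2, at the same place. Resting on a number 7.1 percentage points higher from compound 1 to compound 2 (within the scatter) and on the value of compound 3, 76%, the expected step is a number 7 percentage points higher from compound 3 to compound 4 (within the scatter). Compound 4 is therefore estimated at 83%, between 70% and 93%.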

Compound 4, a percentage reported as inhibition, at one concentration (the size of the read-out at that concentration, not a potency): 78.3%
For compound 4 the middle estimate is 4.7 percentage points above the measured one; the range from low to high includes it.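

On the core of compound 3, pyrrolidin-1-yl in place of dimethylamino gives a number 2.3 percentage points higher from compound 3 to compound 4 (within the scatter) in this assay, and this agrees with the step seen on the core of compound 1: the same change on two cores in this assay, a number 7.1 percentage points higher (within the scatter) from compound 1 to compound 2 and a number 2.3 percentage points higher (within the scatter) from compound 3 to compound 4, 4.8 percentage points apart, within the scatter of two such steps
Hydrogen in place of phenyl, with pyrrolidin-1-yl on the chain, gives a number 14.4 percentage points lower from compound 2 to compound 4 (beyond the scatter), which likewise agrees with the earlier step: the same change on two cores in this assay, a number 9.6 percentage points lower (within the scatter) from compound 1 to compound 3 and a number 14.4 percentage points lower (beyond the scatter) from compound 2 to compound 4, 4.8 percentage points apart, within the scatter of two such steps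
Both steps for the amine change lie within the scatter, so the two pairs show that it carries over consistently but not that it raises inhibition, and they say nothing about potency or about cores beyond these two.

The compounds shown leave open how a piperidine or a morpholine would behave in place of these amines. They also leave open what a shorter or longer chain to the sulfur would do.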